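A few compounds are considered here, and "the series" means these few. Any claim that something is new, unique, unknown or untested is made for them only; others in the source may bear on it.

Compound 1 `COc1ccc(C2=C(c3ccc(SC)cc3)CC3CCCN3C2=O)cc1O` gives 6000 nM in a functional assay on NCI-H520 cells (Homo sapiens) for cytotoxicity; a lower number here means a stronger inhibitor of growth, a higher number a weaker inhibitor of growth. Compound 2 `CSc1ccc(C2=C(c3ccc(F)c(F)c3)C(=O)N3CCCC3C2)cc1` gives 200 nM in this assay, the lowest of the two numbers, separated from compound 1 by the step of a 30-fold lower number from compound 1 to compound 2 (1.48 log units; beyond the scatter). The unmeasured compound 3 `CSc1ccc(C2=C(c3ccc(SC)cc3)C(=O)N3CCCC3C2)cc1` differs from compound 2 as follows: 4-(methylsulfanyl)phenyl in place of 3,4-difluorophenyl on a double-bonded ring carbon. Among the compounds with values here, no measured step exchanges 3,4-difluorophenyl for 4-(methylsulfanyl)phenyl; the single large step of a 30-fold lower number from compound 1 to compound 2 (1.48 log units; beyond the scatter) concerns a different group and offers no direct guide. The expected step is therefore a 1.5-fold higher number from compound 2 to compound 3 (0.18 log units; within the scatter), within the scatter. For compound 3 the estimate is 300 nM, in a range from 80 nM to 1200 nM.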

Compound 3, concentration for 50% growth inhibition: 15000 nM
For compound 3 the middle estimate is 50-fold (1.70 log units) below the measured one; measured number above the stated range.
By their numbers in this assay, from the lowest: compound 2; then compound 1; then compound 3.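

In this assay this double-bonded ring carbon proves highly sensitive to the group it carries, even though both groups have the same heavy-atom count and one aromatic ring: the exchange gives a 75-fold higher number from compound 2 to compound 3 (1.88 log units; beyond the scatter). The further step a 2.5-fold higher number from compound 1 to compound 3 (0.40 log units; beyond the scatter) places 4-(methylsulfanyl)phenyl behind 3-hydroxy-4-methoxyphenyl here, so of the three groups, 3,4-difluorophenyl gives by far the lowest number. Nothing measured accounts for this sensitivity. As far as these compounds go, it remains open whether a single fluorine, a chlorine, an amine or a carboxylic acid on this phenyl ring would keep the number of compound 2.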